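Swapping the Sulfonyl Cap for a Carbamate

The compounds below may be only part of what the source reports. "The series", "measured", "known", "first", "only" and "open" are said of these compounds alone.

Among the compounds with values here, compound 2 `CC[C@H](C)[C@H](NC(=O)c1cccc(Cn2ccnc2)c1)C(=O)NNS(=O)(=O)c1c(C)cc(C)cc1C` is the only compound here with a number: in an assay on HEK293 cells for displacement of a labelled ligand from Type-2 angiotensin II receptor (Homo sapiens) (a higher number here means a weaker inhibitor, a lower number a stronger inhibitor), compound 2 gives 8500 nM, a weak result. Compound 1 `CCCCNC(=O)[C@@H](NC(=O)c1cccc(Cn2ccnc2)c1)[C@@H](C)CC` shares the core but carries a butylamide in place of the hydrazide, and in this assay compound 1 gives "not determined" (no result reported), so it offers no comparison. Compound 3 `CC[C@H](C)[C@H](NC(=O)c1cccc(Cn2ccnc2)c1)C(=O)NNC(=O)OC(C)(C)C` is the not yet measured analogue; its change from compound 2 is tert-butoxycarbonyl in place of (2,4,6-trimethylphenyl)sulfonyl on an amine nitrogen, so the aromatic ring on that end of the molecule is gone. Within the data shown here, no pair of measured compounds shows what this kind of exchange does, so the direction must be guessed. Compound 3 is expected to be somewhat weaker than compound 2, with a step of a 2.4-fold higher number from compound 2 to compound 3 (0.37 log units; beyond the scatter) that may exceed the usual scatter. Compound 3 is therefore estimated at 20000 nM in this assay, within a range from 5000 nM to 80000 nM.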

Compound 3, inhibition constant: > 100000 nM
Compound 3: only a limit was reported (the forecaster's own chance of this, stated with the estimate: 35%); middle value at least 5.0-fold (0.69 log units) from the limit.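

In this assay, placing tert-butoxycarbonyl instead of (2,4,6-trimethylphenyl)sulfonyl on this amine nitrogen gives an at least 11-fold higher number from compound 2 to compound 3 (1.07 log units; beyond the scatter), so binding is sensitive to the group carried here. The incoming group has no ring and fewer heavy atoms, yet the two groups have equal counts of hydrogen-bond donors and acceptors, so those counts do not separate the two results. Compound 3 has a limit of the assay rather than a number, so the full size of the step stays unknown: the limit of > 100000 nM in this assay, at which 1 of the 3 values shown sits.

This single exchange changes the ring, the sulfonyl and the size of the group together, so the compounds shown cannot say which of these matters. A benzyloxycarbonyl group would restore an aromatic ring on a carbamate, while a methanesulfonyl group would keep the sulfonyl without the ring.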